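The source may report more compounds than this note shows. Statements on the series, on what has been measured and on what is new or still open speak of the compounds shown alone.

Measured compounds:
compound 1, `O=S(=O)(Nc1ccc2oc(-c3ccccc3)nc2c1)c1cccc(F)c1`; compound 2, `O=S(=O)(Nc1ccc2oc(-c3ccccc3)nc2c1)c1cccs1`.

In an assay on cells for inhibition of HSP60/HSP10 (Homo sapiens), with a stated time of 60 min (a lower number here means a stronger inhibitor, a higher number a weaker inhibitor), compound 1 gives only a limit, > 100000 nM. In this assay compound 2 gives 90000 nM, and this is the only true number shown. The other value shown, that of compound 1, is a limit, (the limit of > 100000 nM in this assay, at which 1 of the 2 values shown sits). Within the data shown here, the single measured step, an at least 1.1-fold lower number from compound 1 to compound 2 (0.04 log units; that floor lies within the scatter), has its floor within the scatter, so the two compounds cannot be ranked against each other. Compound 3, `COc1ccc(S(=O)(=O)Nc2ccc3oc(-c4ccccc4)nc3c2)cc1`, differs from compound 2 in one place: 4-methoxyphenyl in place of thiophen-2-yl on a sulfonyl sulfur. Among the measured compounds shown here, no measured step exchanges an aromatic ring on the sulfonyl sulfur for a 4-methoxyphenyl group, so the only guide is that the one change made on the sulfonyl sulfur, from compound 1 to compound 2, did not move the number beyond the scatter. The expected step is a 1.1-fold lower number from compound 2 to compound 3 (0.05 log units; within the scatter). For compound 3 the estimate is 80000 nM, with a range from 20000 nM to 300000 nM, and a real chance that this assay again reports only a limit.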

Compound 3, half-maximal inhibitory concentration: > 100000 nM
Compound 3: only a limit was reported (the forecaster's own chance of this, stated with the estimate: 40%); middle value at least 1.2-fold (0.09 log units) away from the limit.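

In this assay the exchange on the sulfonyl sulfur gives an at least 1.1-fold higher number from compound 2 to compound 3 (0.04 log units; that floor lies within the scatter), so compound 2 and compound 3 cannot be ranked against each other. Compound 1 and compound 3 each carry only a limit, and the step between them cannot be read. A six-membered aromatic ring bearing a methoxy group has now joined the thiophen-2-yl and 3-fluorophenyl groups at this place, and none of the three is separated from the others, with limits now making up most of the results: the limit of > 100000 nM in this assay, at which 2 of the 3 values shown sit.

Still open, going by these compounds, is whether a group of another kind on the sulfonyl sulfur, such as a short alkyl chain or a phenyl ring carrying an amine or a carboxylic acid, would give a clearly lower number. Also open, on these data alone, is whether any change elsewhere on the shared core would do so.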